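The source may report more compounds than this note shows. Statements on the series, on what has been measured and on what is new or still open speak of the compounds shown alone.

Of the compounds shown here, three have been measured in an ADME assay on MDCK cells (Canis lupus familiaris) for cytotoxicity, read by microscopy, with a stated time of 6 days (on this read-out higher numbers stand for lower toxicity in this test and lower numbers for higher toxicity in this test), and a fourth has not. Compound 1 `CCCCCCNc1cnc(C(=O)NCc2ccccc2)cn1` and compound 2 `CCCCNc1cnc(C(=O)NCc2ccccc2)cn1` share one core; compound 3 `CCCCCCCNc1cncc(C(=O)NCc2ccccc2)n1` and compound 4 `CCCCCNc1cncc(C(=O)NCc2ccccc2)n1` share another, and the difference between the two cores is not broken down here.

In this assay compound 1 gives > 100000 nM, which is a limit of the assay and not a number (the limit of > 100000 nM in this assay, at which 1 of the 3 values shown sits). In this assay compound 2 gives 100000 nM. The change between them is hydrogen in place of ethyl on a saturated chain carbon, four bonds along the chain from a nitrogen on an aromatic ring and the step it made is a number no higher from compound 1 to compound 2 (the limit leaves the size open).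

In this assay, for the measured compounds named here, compound 3 gives 4000 nM, the lowest of the numbers so far, with compound 2 standing nearest at a clearly higher value.

Compound 4 differs from compound 3 by hydrogen in place of ethyl on a saturated chain carbon, five bonds along the chain from a nitrogen on an aromatic ring. This is the same kind of change as that from compound 1 to compound 2, but the place is not identical: there the carbon lies four bonds along the chain from a nitrogen on an aromatic ring, here five bonds along the chain. Since the measured step of a number no higher from compound 1 to compound 2 (the limit leaves the size open) is open in size, there is little to set the expected step against. The expected step is estimated as a 2.0-fold higher number from compound 3 to compound 4 (0.30 log units; within the scatter), a modest change. This expectation rests on the step of a number no higher from compound 1 to compound 2 (the limit leaves the size open) and on the value that compound 3 gives, 4000 nM. Compound 4 is therefore estimated at 8000 nM, with a range from 2000 nM to 40000 nM.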

Compound 4, minimum cytotoxic concentration: 20000 nM
Compound 4: middle estimate off by 2.5-fold (0.40 log units), on the low side; the range from low to high includes it.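

In this assay, hydrogen in place of ethyl gives a 5.0-fold higher number from compound 3 to compound 4 (0.70 log units; beyond the scatter), and this does not match what the same kind of change did on the core of compound 1, so the change does not carry over unaltered from one core to the other: the same change on two cores in this assay, a number no higher (the limit leaves the size open) from compound 1 to compound 2 and a 5.0-fold higher number (0.70 log units; beyond the scatter) from compound 3 to compound 4, at least 5.0-fold (0.69 log units) apart, beyond the scatter of two such steps. Compound 1 gives > 100000 nM, which is a limit of the assay and not a number, so the step on that core cannot be read for size: the limit of > 100000 nM in this assay, at which 1 of the 4 values shown sits. This comparison does not show that the core alone sets the difference, as it rests on one pair per core and the changed carbon lies four bonds along the chain from a nitrogen on an aromatic ring in one pair and five bonds along the chain in the other.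

The compounds shown leave open how the read-out would run on either core with a longer chain, or with an amine or a carboxylic acid on the chain in place of the ethyl. They also leave open whether the change, made at the same place on both cores, would give two steps of readable size that agree.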